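The compounds below may be only part of what the source reports. "The series", "measured", "known", "first", "only" and "open" are said of these compounds alone.

Of the compounds shown here, three sharing one core have been measured in a functional assay on Jurkat cells (Homo sapiens); on this read-out higher numbers stand for weaker inhibition and lower numbers for stronger inhibition: compound 1 `C[C@H](NC(=O)C(=O)NCC1CCCCC1)C(=O)N[C@@H](CC(=O)O)C(=O)COc1c(F)c(F)cc(F)c1F` gives 19 nM, compound 2 `C[C@H](NC(=O)C(=O)NCC1(c2ccccc2)CC1)C(=O)N[C@@H](CC(=O)O)C(=O)COc1c(F)c(F)cc(F)c1F` gives 27 nM and compound 3 `Cc1ccccc1CNC(=O)C(=O)N[C@@H](C)C(=O)N[C@@H](CC(=O)O)C(=O)COc1c(F)c(F)cc(F)c1F` gives 52 nM. Compound 3 has the highest number of the three, but only one of its two gaps counts as real: the data show a 1.9-fold higher number from compound 2 to compound 3 (0.28 log units; within the scatter), and also a 2.7-fold higher number from compound 1 to compound 3 (0.44 log units; beyond the scatter).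

The next compound, compound 4 `C[C@H](NC(=O)C(=O)NCc1cccc(F)c1)C(=O)N[C@@H](CC(=O)O)C(=O)COc1c(F)c(F)cc(F)c1F`, differs from compound 3 by one swap: 3-fluorophenyl in place of 2-methylphenyl on a saturated chain carbon bound to an amide-type nitrogen. In words, 3-fluorophenyl stands in place of 2-methylphenyl on a saturated chain carbon bound to an amide-type nitrogen.

Among the measured compounds shown here, no measured step swaps one phenyl group for another substituted phenyl group, so the evidence is indirect. Even replacing the whole group gave only a 1.4-fold higher number from compound 1 to compound 2 (0.15 log units; within the scatter) and, at most, the modest 2.7-fold higher number from compound 1 to compound 3 (0.44 log units; beyond the scatter). A smaller swap is therefore expected to give no step beyond the scatter in this assay.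

The expected step is a 1.2-fold lower number from compound 3 to compound 4 (0.06 log units; within the scatter). For compound 4 the estimated value is 45 nM, with an expected range from 20 nM to 100 nM.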

Compound 4, half-maximal inhibitory concentration: 106 nM
Compound 4: middle estimate off by 2.4-fold (0.37 log units), on the low side; measured number outside the range, above it.
By their numbers in this assay, from the lowest: compounds 1, 2 and 3 (each within the scatter of the next, the first and the last beyond it); then compound 4.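

Replacing 2-methylphenyl with 3-fluorophenyl, two groups with 7 heavy atoms and the same aromatic ring, still gives a 2.0-fold higher number from compound 3 to compound 4 (0.31 log units; beyond the scatter) in this assay, so this position responds to a change on the ring itself and not only to replacing the whole group. The gaps to the non-benzyl groups are larger, with a 3.9-fold higher number from compound 2 to compound 4 (0.59 log units; beyond the scatter) and a 5.6-fold higher number from compound 1 to compound 4 (0.75 log units; beyond the scatter), which makes compound 4 the weakest inhibitor of the four, since all its steps lie beyond the scatter. Nothing measured here explains why this swap matters.

This swap changes both the substituent and its location on the ring, and the compounds shown cannot separate those two changes. A 2-fluorophenyl or 3-methylphenyl group would separate them, and a plain phenyl group would show how either substituent compares with none.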